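The source may report more compounds than this note shows. Statements on the series, on what has been measured and on what is new or still open speak of the compounds shown alone.

Notes on the series. Going by the values given here, the shared core is carried by compound 1 `Cc1ncc2cnnc(O)n12` and compound 2 `CCc1nc(C)c2cnnc(O)n12`; the one unmeasured member is compound 3 `Cc1nc(C)n2c(O)nncc12`. In a functional assay for inhibition, with Homo sapiens as the target (a lower number here means a stronger inhibitor, a higher number a weaker inhibitor), compound 1 reaches only the limit of the assay, > 48000 nM, and not a number. In this assay compound 2 likewise stops at the limit, > 48000 nM, so its standing on the numbers shown is that limit alone. Among the compounds with values here, both values shown sit at the limit of > 48000 nM in this assay, at which 2 of the 2 values shown sit, so no step between measured compounds can be sized here. The change from compound 2 to compound 3 is hydrogen in place of methyl on a saturated chain carbon bound to an aromatic carbon, which one bond further out reads ethyl to methyl. With both measured values at the same limit, the step expected in this assay is a step that the limit leaves unreadable from compound 2 to compound 3, none beyond the scatter. Compound 3 is therefore estimated at 100000 nM in this assay, within 30000 nM to 500000 nM, most likely reported again only as a limit.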

Compound 3, half-maximal inhibitory concentration: > 48000 nM
Compound 3 ended at the assay's limit; the forecaster's own chance of this, stated with the estimate: 90%; the middle value does not contradict the limit.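

In this assay no new step can be read among compound 1, compound 2 and compound 3, because all three values are limits and not numbers: the limit of > 48000 nM in this assay, at which 3 of the 3 values shown sit. The compounds shown leave open how strongly any of them inhibits, and whether any change to the shared core would give a readable number.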